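Swapping the aryl arm of a pyridine core for pyridin-2-yl

The source may hold more compounds than are shown below. What is called first, only, known or untested is meant among the compounds shown, and "the series" means these compounds.

Measured so far:
compound 1 `Clc1ccc(-c2cc(-c3ccoc3)cc(-c3ccco3)n2)s1` with 9.6%
compound 2 `Cc1cccc(-c2cc(-c3ccoc3)cc(-c3ccc(Cl)s3)n2)c1` with 2.6%
compound 3 `Clc1cccc(-c2cc(-c3ccoc3)cc(-c3ccc(Cl)s3)n2)c1` with 2.1%

All three numbers come from an assay on isolated protein for inhibition of DNA topoisomerase 1 (Homo sapiens), with a stated time of 30 min, tested at 100 uM; on this read-out lower numbers stand for less inhibition and higher numbers for more inhibition at the one concentration tested (going by the name of the read-out). Compound 3 holds the lowest of the three numbers, but that standing carries little weight: a number 0.5 percentage points lower from compound 2 to compound 3 (within the scatter) and a number 7.5 percentage points lower from compound 1 to compound 3 (within the scatter) are both within the scatter, so the three compounds cannot be told apart on this read-out.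

The next compound, compound 4 `Clc1ccc(-c2cc(-c3ccoc3)cc(-c3ccccn3)n2)s1`, differs from compound 3 in one place: pyridin-2-yl in place of 3-chlorophenyl on an aromatic carbon.

Among the compounds with values here, no measured pair exchanges 3-chlorophenyl for pyridin-2-yl, so the bearing steps are those that vary the same arm of the shared core. a number 7 percentage points lower from compound 1 to compound 2 (within the scatter) and a number 7.5 percentage points lower from compound 1 to compound 3 (within the scatter) show that replacing furan-2-yl with either a 3-methylphenyl or a 3-chlorophenyl group left this assay essentially unchanged, and a number 0.5 percentage points lower from compound 2 to compound 3 (within the scatter) shows the same for chloro against methyl. Three different groups at this position gave numbers within the scatter of one another; nothing seen here points to pyridin-2-yl behaving differently.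

Compound 4 is therefore expected to give 5%, within -5% to 15% in this assay. The expected step of a number 2.9 percentage points higher from compound 3 to compound 4 (within the scatter) is one that stays inside the scatter, with no direction that can be read as real.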

Compound 4, a percentage reported as inhibition, at one concentration (the size of the read-out at that concentration, not a potency): 3.1%
Compound 4: the middle estimate sits 1.9 percentage points above what was measured; low and high end bracket the measured number.
By their numbers in this assay, from the lowest: compounds 3, 2, 4 and 1 (each within the scatter of the next).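

Pyridin-2-yl places a six-membered aromatic ring with 1 hetero atom and 1 hydrogen-bond acceptor at this position, where 3-chlorophenyl and 3-methylphenyl have carbon-only rings and 0 hydrogen-bond acceptors, yet this assay shows a number 1 percentage points higher from compound 3 to compound 4 (within the scatter) and a number 0.5 percentage points higher from compound 2 to compound 4 (within the scatter) and also a number 6.5 percentage points lower from compound 1 to compound 4 (within the scatter) against the five-membered furan-2-yl arm. All four groups at this position therefore remain within the scatter of one another, so neither the ring nitrogen of the new arm nor the change of ring size separates any of these compounds at the one concentration tested. Nothing available explains why this arm leaves the read-out without a discernible change.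

The compounds shown leave open whether an arm bearing an amine or a carboxylic acid, or a longer chain such as an aminoalkyl group in place of the ring, would move the number beyond the scatter. They also leave open what happens when the furan-3-yl group or the 5-chlorothiophen-2-yl group, which all four compounds share, is replaced by another group.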